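Two Aryl Exchanges at One Carbon of the Shared Core

The source may hold more compounds than are shown below. What is called first, only, known or untested is meant among the compounds shown, and "the series" means these compounds.

Compound 1 `Cc1ccc(-c2cc(-c3ccoc3)cc(-c3ccc(Cl)s3)n2)o1` gives 33400 nM
Compound 2 `Clc1cccc(-c2cc(-c3ccoc3)cc(-c3ccc(Cl)s3)n2)c1` gives 23000 nM

For the measured compounds named here, both numbers come from a functional assay on DU-145 cells (Homo sapiens) for cytotoxicity, read by ELISA, with a stated time of 4 days (on this read-out higher numbers stand for weaker inhibition and lower numbers for stronger inhibition), where the only measured step is a 1.5-fold lower number from compound 1 to compound 2 (0.16 log units; within the scatter). Compound 2 therefore cannot be separated from compound 1 on these numbers, and the two values form a single level rather than a ranking.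

Compound 3 `Clc1ccc(-c2cc(-c3ccoc3)cc(-c3ccccn3)n2)s1` has not yet been measured. It keeps the core of compound 2, but pyridin-2-yl stands in place of 3-chlorophenyl on an aromatic carbon, next to the ring nitrogen: pyridin-2-yl in place of 3-chlorophenyl on an aromatic carbon. Going by the values given here, the one measured step bears directly on this change, since it exchanged one aromatic group for another at the same place. That exchange gave a 1.5-fold lower number from compound 1 to compound 2 (0.16 log units; within the scatter), so a further exchange there is expected to leave the number in this assay about where it is, with no clear direction. Among the compounds with values here, no measured compound carries pyridin-2-yl, so this evidence is thin. The expected step is a 1.2-fold lower number from compound 2 to compound 3 (0.06 log units; within the scatter), which is no change beyond the scatter. For compound 3 the estimated value is 20000 nM, with an expected range from 7000 nM to 50000 nM.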

Compound 3, half-maximal inhibitory concentration: 20500 nM
Estimate against measurement, compound 3: 1.0-fold (0.01 log units) below; the measured number falls inside the stated range.
By their numbers in this assay, from the lowest: compounds 3, 2 and 1 (each within the scatter of the next).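

Pyridin-2-yl brings a ring nitrogen and a hydrogen-bond acceptor to this aromatic carbon in place of the carbon-only ring of 3-chlorophenyl, yet in this assay the exchange gives a 1.1-fold lower number from compound 2 to compound 3 (0.05 log units; within the scatter), and measured against 5-methylfuran-2-yl at the same carbon it gives a 1.6-fold lower number from compound 1 to compound 3 (0.21 log units; within the scatter). The earlier pair had shown only two aromatic groups at this place, whereas three now share a single level within the scatter, so neither the chlorine of 3-chlorophenyl, nor the methyl of 5-methylfuran-2-yl, nor the ring nitrogen of pyridin-2-yl separates one compound from another in this read-out. Nothing measured here explains this flat result.

From the compounds shown here alone, all three groups at this carbon are single aromatic rings, so it remains open whether an amine, a carboxylic acid or a longer alkyl chain there would move the number beyond the scatter. The compounds shown also leave open how the number responds to exchanges at the places held by the furan-3-yl and 5-chlorothiophen-2-yl groups, which stay the same throughout.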